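From Methyl to Pentyl in an Antiproliferative Series

The source may report more compounds than this note shows. Statements on the series, on what has been measured and on what is new or still open speak of the compounds shown alone.

For the measured compounds named here, in a functional assay on MCF7 cells (Homo sapiens) for antiproliferative activity, with a stated time of 5 days (a lower number here means a stronger inhibitor, a higher number a weaker inhibitor), compound 2 (`COc1ccc(-c2[nH]c3ccc(C)cc3c2C=O)cc1`) gives 140 nM and holds the highest of the three numbers so far. Compound 3 (`COc1ccc(-c2[nH]c3ccc(C(C)C)cc3c2C=O)cc1`) gives 97 nM and lies within the scatter of compound 2, while compound 1 (`COc1ccc(-c2[nH]c3cc(Cl)c(C)cc3c2C=O)cc1`) gives 62 nM and stands below compound 2 by more than the scatter.

Compound 4 (`CCCCCc1ccc2[nH]c(-c3ccc(OC)cc3)c(C=O)c2c1`) carries pentyl where compound 2 carries methyl. The change is butyl in place of hydrogen on a saturated chain carbon bound to an aromatic carbon with butyl in place of hydrogen on a saturated chain carbon bound to an aromatic carbon.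

The nearest measured precedent is a 1.4-fold lower number from compound 2 to compound 3 (0.16 log units; within the scatter) for isopropyl in place of methyl on an aromatic carbon, and that step stays within the scatter. The other measured step is a 2.3-fold higher number from compound 1 to compound 2 (0.35 log units; beyond the scatter) for hydrogen in place of chloro, which is modest and concerns a different group, so it bears only weakly here. Going by the values given here, no pentyl compound has yet been measured, so the direction remains open and the range must stay wide. The expected move is a 1.1-fold lower number from compound 2 to compound 4 (0.03 log units; within the scatter) and no clear shift beyond the scatter is anticipated. In this assay compound 4 is estimated at 130 nM with a range from 40 nM to 500 nM as the expected span.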

Compound 4, half-maximal inhibitory concentration: 20 nM
For compound 4 the middle estimate is 6.5-fold (0.81 log units) above the measured one, outside the stated range (below it).
By their numbers in this assay, from the lowest: compound 4; then compounds 1, 3 and 2 (each within the scatter of the next, the first and the last beyond it).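

In this assay, the position that had seemed to tolerate change without response turns out to respond strongly to chain length: methyl to pentyl gives a clear gain (a 7.0-fold lower number from compound 2 to compound 4 (0.85 log units; beyond the scatter)), whereas the earlier swap of methyl for isopropyl stayed within the scatter (a 1.4-fold lower number from compound 2 to compound 3 (0.16 log units; within the scatter)). Pentyl also separates from isopropyl at the same place (a 4.9-fold lower number from compound 3 to compound 4 (0.69 log units; beyond the scatter)), so the gain is not simply shared by every alkyl group larger than methyl among the three compared here. Nothing measured alongside these numbers speaks to why the pentyl compound behaves this way.

With only methyl, isopropyl and pentyl at this place, the compounds shown do not reveal whether the number falls steadily with each added carbon or only once the chain reaches a certain length, nor whether a longer chain such as octyl would extend the gain or lose it. They also leave open whether a pentyl chain ending in an amine or a hydroxyl group would keep the gain, and whether the chloro substituent of compound 1 would add to it.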